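Thiophene Carbonyl on the Aniline Nitrogen: Effect on Tolerance

The source may hold more compounds than are shown below. What is called first, only, known or untested is meant among the compounds shown, and "the series" means these compounds.

Compound 1 `Nc1ccc(C(=O)/C=C/c2ccco2)cc1`: 90000 nM
Compound 2 `O=C(/C=C/c1ccco1)c1ccc(NC(=O)c2cccs2)cc1`: 93000 nM
Compound 3 `Nc1ccc(C(=O)/C=C/c2ccccc2)cc1`: > 100000 nM (a limit of the assay)

In a toxicity assay on FHC cells (Homo sapiens) for cytotoxicity, read by resazurin assay, with a stated time of 48 h (a lower number here means that less compound is tolerated, a higher number that more compound is tolerated), compound 1 gives 90000 nM and compound 2 gives 93000 nM. For compound 3 the assay reports only a limit, > 100000 nM. The difference between the cores of compound 1 and compound 3 is not broken down here. From compound 1 to compound 2 the change is (thiophen-2-yl)carbonyl in place of hydrogen on a nitrogen on an aromatic ring, and it gives a 1.0-fold higher number from compound 1 to compound 2 (0.01 log units; within the scatter). Compound 4 `O=C(/C=C/c1ccccc1)c1ccc(NC(=O)c2cccs2)cc1` has not yet been measured; it carries the same change on the core of compound 3, namely ((thiophen-2-yl)carbonyl in place of hydrogen on a nitrogen on an aromatic ring). Because a 1.0-fold higher number from compound 1 to compound 2 (0.01 log units; within the scatter) stays within the scatter and compound 3 sits at the limit of > 100000 nM in this assay, at which 1 of the 3 values shown sits, compound 4 is expected to show a step that the limit leaves unreadable from compound 3 to compound 4. In this assay compound 4 is estimated at 110000 nM, between 60000 nM and 250000 nM, most probably reported again only as a limit.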

Compound 4, half-maximal cytotoxic concentration: 83000 nM
Estimate against measurement, compound 4: 1.3-fold (0.12 log units) above, within the range that was stated.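

In this assay the value of compound 3 is only a limit, > 100000 nM. Placing (thiophen-2-yl)carbonyl on the nitrogen of this core gives an at least 1.2-fold lower number from compound 3 to compound 4 (0.08 log units; that floor lies within the scatter), while phenyl in place of furan-2-yl gives a 1.1-fold lower number from compound 2 to compound 4 (0.05 log units; within the scatter). The step on the core of compound 1 lies within the scatter, but the step on the core of compound 3 has only a floor, so it is not shown that the change carries over from one core to the other unaltered: the same change on two cores in this assay, a 1.0-fold higher number (0.01 log units; within the scatter) from compound 1 to compound 2 and an at least 1.2-fold lower number (0.08 log units; that floor lies within the scatter) from compound 3 to compound 4; the limit leaves it open whether they differ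

The compounds shown leave open how an acetyl or a benzoyl group in place of hydrogen on the same nitrogen would read in this assay. They also leave open how large the step to compound 4 really is.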